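The source may report more compounds than this note shows. Statements on the series, on what has been measured and on what is new or still open speak of the compounds shown alone.

Compound 1 `COc1ccc2c(=O)c(/C=C/C(=O)Nc3cccc(C)c3)coc2c1` gives 554000 nM in an ADME assay on HepG2 2.2.15 cells (Homo sapiens) for cytotoxicity, read by MTT assay, with stated times of 48 h and 9 days; a lower number here means that less compound is tolerated, a higher number that more compound is tolerated.
Compound 2 `O=C(/C=C/c1coc2cc(O)ccc2c1=O)NCc1ccccc1` gives 436000 nM in this assay.
Compound 3 `COc1ccc2c(=O)c(/C=C/C(=O)NCc3cccc(F)c3)coc2c1` gives 475000 nM in this assay.

Compound 3 stands second highest of these three numbers, and its gaps to compound 2 and to compound 1 are both within the scatter, so the three compounds read alike. The step to compound 4 `COc1ccc2c(=O)c(/C=C/C(=O)Nc3ccccc3C)coc2c1` is 2-methylphenyl in place of 3-fluorobenzyl on an amide-type nitrogen. For the measured compounds named here, the one measured step that touches this position, a 1.2-fold lower number from compound 1 to compound 3 (0.07 log units; within the scatter), was within the scatter, and compound 1 itself carries a 3-methylphenyl on the same nitrogen, a close relative of the incoming group. Therefore the step of a 1.1-fold higher number from compound 3 to compound 4 (0.02 log units; within the scatter) is expected to stay within the scatter, with no clear direction. Compound 4 is estimated at 500000 nM, within a range of 250000 nM to 1000000 nM.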

Compound 4, half-maximal cytotoxic concentration: 59700 nM
Compound 4: middle estimate off by 8.4-fold (0.92 log units), on the high side; measured number outside the range, below it.
By their numbers in this assay, from the lowest: compound 4; then compounds 2, 3 and 1 (each within the scatter of the next).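

This position on the amide-type nitrogen can matter after all: in this assay, 2-methylphenyl in place of 3-methylphenyl gives a 9.3-fold lower number from compound 1 to compound 4 (0.97 log units; beyond the scatter) even though the two groups are close relatives. The change from 3-fluorobenzyl gives an 8.0-fold lower number from compound 3 to compound 4 (0.90 log units; beyond the scatter) and is also beyond the scatter, whereas the earlier step at this nitrogen stayed within it. Nothing measured here explains the lower number.

Going by these compounds, whether it belongs to the 2-methylphenyl alone remains open. So does what a 2-chlorophenyl or a 2-methoxyphenyl on this nitrogen would give.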